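Cyclopropyl for Ethyl on the Amide-Bearing Carbon

The source may report more compounds than this note shows. Statements on the series, on what has been measured and on what is new or still open speak of the compounds shown alone.

Of the compounds shown here, two have been measured in a functional assay with platelet-activating factor receptor (Cavia porcellus) as the target; on this read-out higher numbers stand for an effect only at larger amounts of compound and lower numbers for an effect already at smaller amounts. Compound 1, `CC[C@H](CCCc1cccnc1)NC(=O)/C=C/C=C(c1ccc(OC)cc1)c1ccc(OC)cc1`, gives 0.16 mg/kg in this assay and holds the lower of the two numbers. Compound 2, `CC/C(=C\C=C\C(=O)N[C@H](C)CCCc1cccnc1)c1ccc(OC)cc1`, gives 0.68 mg/kg in this assay, a number that sits above that of compound 1 by more than the scatter allows. Among the measured compounds shown here, the two structures differ in several places at once, so no single step between them can be read off, and the gap says nothing about any one group.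

The next compound, compound 3, `COc1ccc(C(=C/C=C/C(=O)N[C@@H](CCCc2cccnc2)C2CC2)c2ccc(OC)cc2)cc1`, is compound 1 with a single change: cyclopropyl in place of ethyl on a saturated chain carbon bound to an amide-type nitrogen and a saturated chain carbon. For the measured compounds named here, nothing among the measured compounds shows what this particular change does in this assay, and the shared core is otherwise kept as in compound 1. With no guide in either direction, the change is expected to leave the number close to where compound 1 stands; the estimated step is no change at the digits printed from compound 1 to compound 3 (within the scatter), not beyond the scatter. Compound 3 is therefore expected to give about 0.16 mg/kg in this assay, with a range from 0.05 mg/kg to 0.5 mg/kg.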

Compound 3, dose for 50% inhibition: 0.2 mg/kg
For compound 3 the middle estimate is 1.3-fold (0.10 log units) below the measured one, within the range that was stated.
By their numbers in this assay, from the lowest: compounds 1 and 3 (each within the scatter of the next); then compound 2.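

With cyclopropyl in place of ethyl on a saturated chain carbon bound to an amide-type nitrogen and a saturated chain carbon, this assay shows a 1.3-fold higher number from compound 1 to compound 3 (0.10 log units; within the scatter) and thus gives the series its first step that can be read at a single place. The earlier pair could not show this, since compound 1 and compound 2 differ in several places at once; now it is clear that this carbon can carry a three-membered non-aromatic ring, with one more heavy atom than ethyl, and the number in this read-out stays within the scatter of that of compound 1. Nothing available explains why the exchange leaves the number where it is, and no property of either group can be drawn from this step.

Going by these compounds, whether the same holds for other groups on this carbon remains open, for instance a longer chain such as n-butyl, a larger ring such as cyclohexyl, a phenyl ring, or a group carrying an amine or a carboxylic acid. The step also leaves open whether cyclopropyl would behave the same way on a different core, such as that of compound 2, whose other differences from compound 1 still cannot be read one by one.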